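The source may hold more compounds than are shown below. What is called first, only, known or untested is meant among the compounds shown, and "the series" means these compounds.

Notes on the series. In a functional assay on MCF7 cells (Homo sapiens) for inhibition, read by MTT assay, with a stated time of 72 h (on this read-out lower numbers stand for stronger inhibition and higher numbers for weaker inhibition), compound 1 `COc1cc(NC(C)CCCNC(=O)Nc2cccc(Cl)c2)c2ncccc2c1` gives 11000 nM, compound 2 `COc1cc(NC(C)CCCNC(=O)NNC(=O)Nc2ccc(F)cc2)c2ncccc2c1` gives 310 nM, and compound 3 `COc1cc(NC(C)CCCNC(=O)NNC(=O)Nc2ccc(C(F)(F)F)cc2)c2ncccc2c1` gives 100 nM, the lowest of the three numbers. Compound 4 `COc1cc(NC(C)CCCNC(=O)NNC(=O)Nc2cccc(F)c2)c2ncccc2c1` has no number yet. It carries 3-fluorophenyl in place of the 4-(trifluoromethyl)phenyl of compound 3 on an amide-type nitrogen: 3-fluorophenyl in place of 4-(trifluoromethyl)phenyl on an amide-type nitrogen.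

Among the measured compounds shown here, two measured steps bear on this change. The large one, a 35-fold lower number from compound 1 to compound 2 (1.55 log units; beyond the scatter), brought in the carbamoylamino unit, which compound 4 keeps, so no return towards the number of compound 1 is expected. The closer guide is a 3.1-fold lower number from compound 2 to compound 3 (0.49 log units; beyond the scatter), a modest step with trifluoromethyl in place of fluoro on an aromatic carbon. Compound 4 gives up that trifluoromethyl and has fluoro again, though as 3-fluorophenyl rather than the 4-fluorophenyl of compound 2. For the measured compounds named here, no measured pair shows what that difference in fluoro placement does, so the range stays wide. A modest step to a higher number in this assay is expected, about the size of the second step run in reverse. The expected change is a 3.0-fold higher number from compound 3 to compound 4 (0.48 log units; beyond the scatter). For compound 4 the estimated value is 300 nM, with an expected range from 110 nM to 800 nM.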

Compound 4, half-maximal inhibitory concentration: 150 nM
Compound 4: the middle estimate sits 2.0-fold (0.30 log units) above what was measured; the measured number falls inside the stated range.
By their numbers in this assay, from the lowest: compounds 3 and 4 (each within the scatter of the next); then compound 2; then compound 1.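

Working notes, position on the amide-type nitrogen: in this assay, the swap of 4-(trifluoromethyl)phenyl for 3-fluorophenyl gives a 1.5-fold higher number from compound 3 to compound 4 (0.18 log units; within the scatter) and so no readable difference, which means that trifluoromethyl is not needed to reach the range of compound 3 in this series. Fluoro placement now has a measured pair, with a 2.1-fold lower number from compound 2 to compound 4 (0.32 log units; beyond the scatter) as a modest step for 3-fluorophenyl in place of 4-fluorophenyl, while a 73-fold lower number from compound 1 to compound 4 (1.87 log units; beyond the scatter) shows that the large step from the plain urea of compound 1 is not tied to 4-fluorophenyl. No measurement at hand accounts for either step.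

Still open is whether an aryl group is needed here at all, since every compound shown carries one and the effect of an amine, a carboxylic acid or a longer chain in its place is unknown. Also open, from the compounds shown here alone, is how 3-chlorophenyl or 3-(trifluoromethyl)phenyl would read with the carbamoylamino unit kept, which would separate the effect of the group from that of its placement.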